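This account rests on a few compounds, and the source may have more. Where it says the series, first, only, none or still open, it means among the compounds named here.

Of the compounds shown here, three built on one shared core have been tested in a functional assay on HUVEC cells (Homo sapiens) for antiproliferative activity, read by MTT assay, with a stated time of 24 h; a higher number here means a weaker inhibitor, a lower number a stronger inhibitor. Compound 1 `COc1cc(OC)c(-c2coc3cc(OCC(=O)c4cccc(C(F)(F)F)c4)ccc3c2=O)cc1OC` carries a (3-(trifluoromethyl)phenyl)carbonyl on a saturated chain carbon bound to an oxygen on an aromatic ring. In this assay compound 1 gives > 10000 nM, which is a limit of the assay and not a number. Compound 2 `COc1cc(OC)c(-c2coc3cc(OCc4ccccc4F)ccc3c2=O)cc1OC` carries a 2-fluorophenyl at that place instead, and in this assay compound 2 gives 4300 nM. Compound 3 `COc1cc(OC)c(-c2coc3cc(OCc4ccc(C#N)cc4)ccc3c2=O)cc1OC` carries a 4-cyanophenyl there, and in this assay compound 3 gives > 10000 nM, again a limit of the assay. Compound 3 therefore stands at the weak end of what the numbers show, at the limit of > 10000 nM in this assay, at which 2 of the 3 values shown sit. The measured steps run as follows: an at least 2.3-fold lower number from compound 1 to compound 2 (0.36 log units; beyond the scatter); an at least 2.3-fold higher number from compound 2 to compound 3 (0.36 log units; beyond the scatter); and a step that the two limits leave unreadable from compound 1 to compound 3.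

Compound 4 `COc1cc(OC)c(-c2coc3cc(OCc4cccc(C(F)(F)F)c4)ccc3c2=O)cc1OC` has not yet been measured. (3-(trifluoromethyl)phenyl in place of 4-cyanophenyl on a saturated chain carbon bound to an oxygen on an aromatic ring). Among the compounds with values here, the only measured step that reaches compound 3 is the one from compound 2, which ended at the limit, and the step from compound 1 to compound 3 cannot be read; neither gives a direction for exchanging one aryl group for another at this place. A number near the limit is therefore expected, with an at least 1.2-fold lower number from compound 3 to compound 4 (0.09 log units; that floor lies within the scatter) as the expected step. For compound 4 the estimate is 8000 nM, within a range of 2500 nM to 30000 nM.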

Compound 4, half-maximal inhibitory concentration: > 10000 nM
Compound 4: a limit, no number (the forecaster's own chance of this, stated with the estimate: 55%); at least 1.2-fold (0.09 log units) between middle value and limit.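

In this assay compound 4 gives > 10000 nM, which is a limit of the assay and not a number. Placing 3-(trifluoromethyl)phenyl instead of 2-fluorophenyl on the saturated chain carbon bound to an oxygen on an aromatic ring gives an at least 2.3-fold higher number from compound 2 to compound 4 (0.36 log units; beyond the scatter), so compound 3 is no longer the only aryl exchange from compound 2 that ends at the limit, and compound 2 remains the only one of the four compounds with a measured number. The steps that join compound 4 to compound 1 and to compound 3 cannot be read, and the series now clusters at one end of the scale: the limit of > 10000 nM in this assay, at which 3 of the 4 values shown sit.

On these data alone, how far compound 1, compound 3 and compound 4 lie beyond the limit remains unknown, so the 4-cyanophenyl, the 3-(trifluoromethyl)phenyl and the (3-(trifluoromethyl)phenyl)carbonyl cannot be ranked against one another. Also open, as far as these compounds go, is whether an unsubstituted phenyl, an aminophenyl, a carboxylic acid or a longer chain at this place would give a measured number, and how any of these would compare with the 2-fluorophenyl of compound 2.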